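Swapping chloro for methyl on the aryl of compound 1

The compounds below may be only part of what the source reports. "The series", "measured", "known", "first", "only" and "open" are said of these compounds alone.

Measured compounds:
- compound 1, `O=C(NO)c1ccc(NCc2nc(-c3cccc(Cl)c3)nn2-c2ccccc2)cc1`, 115 nM
- compound 2, `O=C(NO)c1ccc(NCc2nc(-c3ccccc3)nn2-c2ccc(Br)cc2)cc1`, 1730 nM
- compound 3, `O=C(NO)c1ccc(NCc2nc(-c3ccccc3)nn2-c2cccc(Cl)c2)cc1`, 678 nM

All three were tested in an assay on Sf9 cells for inhibition of protein deacetylase HDAC6 (Homo sapiens), read by fluorescence, with a stated time of 40 min; a higher number here means a weaker inhibitor, a lower number a stronger inhibitor. Compound 1 gives the lowest number of the three, so it is the strongest inhibitor here; compound 3 sits nearest, and compound 2 furthest, both beyond the scatter. Within the data shown here, the one single-point step available, a 2.6-fold lower number from compound 2 to compound 3 (0.41 log units; beyond the scatter), concerns the aromatic ring on the nitrogen of the shared core.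

Compound 4, `Cc1cccc(-c2nc(CNc3ccc(C(=O)NO)cc3)n(-c3ccccc3)n2)c1`, differs from compound 1 elsewhere: methyl in place of chloro on an aromatic carbon, on an aromatic carbon of a six-membered aromatic ring of carbon only. Among the measured compounds shown here, no measured pair probes this position, so the step from compound 2 to compound 3 does not bear on it directly. Without a comparable step, the expectation is a change near or only slightly beyond the scatter, with no clear direction. Compound 4 is therefore expected at 160 nM, in the range 60 nM to 450 nM, meaning an expected step of a 1.4-fold higher number from compound 1 to compound 4 (0.14 log units; within the scatter).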

Compound 4, half-maximal inhibitory concentration: 281 nM
Estimate against measurement, compound 4: 1.8-fold (0.24 log units) below, and the stated range covers the measured number.
By their numbers in this assay, from the lowest: compound 1; then compound 4; then compound 3; then compound 2.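

In this assay, among these compounds, the change from 3-chlorophenyl to 3-methylphenyl gives a 2.4-fold higher number from compound 1 to compound 4 (0.39 log units; beyond the scatter) and thus provides the first reading at this position. Although the step is modest, it shows that this position responds to replacing one heavy atom with another, so chloro and methyl are not interchangeable here. Neither group has a hydrogen-bond donor, a hydrogen-bond acceptor or a net charge, so those counts do not separate them. No measurement available here accounts for the difference.

With only two groups compared at this position, the compounds shown do not establish a trend. They leave open how an amine, a methoxy group or a carboxylic acid in the same place would compare with chloro and methyl.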